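Fluoro in Place of Hydrogen: From Compound 3 to Compound 4

A few compounds are considered here, and "the series" means these few. Any claim that something is new, unique, unknown or untested is made for them only; others in the source may bear on it.

Measured compounds:
compound 1 `Cc1c(CC(=O)O)c2ccccc2n1C(=O)c1ccc(OC[C@@H]2CN(C)c3ccccc3O2)cc1`, 200 nM
compound 2 `COc1cc(C(=O)n2c(C)c(CC(=O)O)c3ccccc32)ccc1OC[C@@H]1CN(C)c2ccccc2O1`, 430 nM
compound 3 `Cc1cc(C(=O)n2c(C)c(CC(=O)O)c3ccccc32)c(C)cc1OC[C@@H]1CN(C)c2ccccc2O1`, 94 nM

In an assay on CHO cells for displacement of a labelled ligand from prostacyclin receptor (Homo sapiens), read by scintillation counting, with a stated time of 30 min (a lower number here means a stronger inhibitor, a higher number a weaker inhibitor), compound 3 stands lowest of the three; compound 1 and compound 2 both give higher numbers, each beyond the scatter. Compound 4 `Cc1cc(C(=O)n2c(C)c(CC(=O)O)c3cc(F)ccc32)c(C)cc1OC[C@@H]1CN(C)c2ccccc2O1` differs from compound 3 by fluoro in place of hydrogen on an aromatic carbon. Among the measured compounds shown here, the only single-place step measured so far, a 2.2-fold higher number from compound 1 to compound 2 (0.33 log units; beyond the scatter), concerns a different group on a different ring, so no measured step bears directly on this change. With nothing to suggest a shift in either direction, the number for compound 4 in this assay is expected to stay close to that of compound 3, the estimated step of a 1.1-fold lower number from compound 3 to compound 4 (0.04 log units; within the scatter) lying within the scatter. Compound 4 is therefore estimated at 85 nM, with a range of 30 nM to 250 nM.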

Compound 4, inhibition constant: 93 nM
Beside the measured number, compound 4's estimate is 1.1-fold (0.04 log units) below it, within the range that was stated.
By their numbers in this assay, from the lowest: compounds 4 and 3 (each within the scatter of the next); then compound 1; then compound 2.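

In this assay, fluoro in place of hydrogen on this ring carbon, meta to a fused ring and para to a fused ring, gives a 1.0-fold lower number from compound 3 to compound 4 (0.00 log units; within the scatter). This is the first step shown on this ring, and it shows that compound 3 accepts a fluoro here with its number staying within the scatter. Nothing available here offers an explanation for this result.

Going by these compounds, whether an amine, a chloro group or a longer chain at this carbon would keep the number within the scatter remains open. So does whether fluoro would behave alike on the other carbons of this ring.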